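This account rests on a few compounds, and the source may have more. Where it says the series, first, only, none or still open, it means among the compounds named here.

Measured in an in vivo ADME assay on the whole organism (strain Sprague-Dawley) for pharmacokinetics, with Rattus norvegicus as the target; on this read-out lower numbers stand for slow clearance and higher numbers for fast clearance:

compound 1, `NCc1ccccc1-c1ccc(C(=O)N2N=C(c3cccnc3)CC2c2ccccc2O)s1`: 65 mL/min/kg
compound 2, `O=C(c1ccc(-c2ccc3c(c2)CNC3)s1)N1N=C(c2cccnc2)CC1c1ccccc1O`: 58.3 mL/min/kg
compound 3, `NCc1ccccc1-c1ccc(C(=O)N2N=C(c3cccnc3)CC2c2c(O)cccc2F)s1`: 26.7 mL/min/kg

Compound 2 holds the second highest of the three numbers. Its nearest neighbour is compound 1, and the step of a 1.1-fold lower number from compound 1 to compound 2 (0.05 log units; within the scatter) shows the two cannot be told apart. Compound 3 sits furthest away, with a number clearly lower than that of compound 2.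

Compound 4, `O=C(c1ccc(-c2ccc3c(c2)CNC3)s1)N1N=C(c2cccnc2)CC1c1c(O)cccc1F`, is not yet measured. It differs from compound 2 by fluoro in place of hydrogen on an aromatic carbon.

The same exchange has been run once already on the other scaffold: a 2.4-fold lower number from compound 1 to compound 3 (0.39 log units; beyond the scatter). That step went beyond the scatter, downward, though modest in size. The scaffold exchange itself, a 1.1-fold lower number from compound 1 to compound 2 (0.05 log units; within the scatter), did not move the number, so compound 2 starts from about the same level as compound 1. On that basis a step of similar size and the same direction is expected here: a 2.2-fold lower number from compound 2 to compound 4 (0.35 log units; beyond the scatter). For the measured compounds named here, with only one precedent the size remains uncertain, and the step could fall closer to the scatter than compound 3 suggests.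

The estimate for compound 4 in this assay is 26 mL/min/kg, with a range from 13 mL/min/kg to 50 mL/min/kg.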

Compound 4, clearance: 15 mL/min/kg
For compound 4 the middle estimate is 1.7-fold (0.24 log units) above the measured one; low and high end bracket the measured number.
By their numbers in this assay, from the lowest: compounds 4 and 3 (each within the scatter of the next); then compounds 2 and 1 (each within the scatter of the next).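

In this assay, the change from 2-hydroxyphenyl to 2-fluoro-6-hydroxyphenyl now has a second instance on a second core, a 3.9-fold lower number from compound 2 to compound 4 (0.59 log units; beyond the scatter), so the drop seen once before is no longer a single observation, and its size carries over between the two cores: the same change on two cores in this assay, a 2.4-fold lower number (0.39 log units; beyond the scatter) from compound 1 to compound 3 and a 3.9-fold lower number (0.59 log units; beyond the scatter) from compound 2 to compound 4, 1.6-fold (0.20 log units) apart, within the scatter of two such steps. The exchange of the aryl group on the thiophene-bearing side, which left the number in place without fluoro, also stays within the scatter with fluoro present, a 1.8-fold lower number from compound 3 to compound 4 (0.25 log units; within the scatter), and the two instances agree: the same change on two cores in this assay, a 1.1-fold lower number (0.05 log units; within the scatter) from compound 1 to compound 2 and a 1.8-fold lower number (0.25 log units; within the scatter) from compound 3 to compound 4, 1.6-fold (0.20 log units) apart, within the scatter of two such steps. Across these four compounds the two changes therefore read as separate, with the fluoro exchange setting the level of the number and the other exchange leaving it in place, and no compound shown goes against this.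

The compounds shown leave open whether chloro or methyl on this same aromatic carbon would give a step of similar size, or whether fluoro is particular in this respect. All four numbers come from this assay alone, and they say nothing about what lies behind the step.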